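Sulfanyl in Place of Benzylamino on a Shared Core

A few compounds are considered here, and "the series" means these few. Any claim that something is new, unique, unknown or untested is made for them only; others in the source may bear on it.

Of the compounds shown here, two have so far been measured in a functional assay (Homo sapiens) for inhibition of Nucleic Acid, tested at 100 uM; a lower number here means less inhibition, a higher number more inhibition at the concentration tested (going by the name of the read-out). Compound 1, `OC[C@H]1O[C@@H](n2cnc3c(NCc4ccccc4)nccc32)C[C@@H]1O`, gives 15% there. Compound 2, `[O-][n+]1ccc2c(c1)ncn2[C@H]1C[C@H](O)[C@@H](CO)O1`, gives 0% in this assay. Of these two numbers, that of compound 1 is the higher, and its nearest neighbour, compound 2, lies lower by more than the usual scatter.

Compound 3, `OC[C@H]1O[C@@H](n2cnc3c(S)nccc32)C[C@@H]1O`, has not yet been measured in this assay. It differs from compound 1 in a single place: sulfanyl in place of benzylamino on an aromatic carbon. Among the compounds with values here, no pair of measured compounds differs in one place, so nothing measured shows what this exchange does on its own; only the two values above can guide an expectation. Since compound 1 gives just 15% in this assay, little room is left for a large downward step, and there is no ground for an upward one. The step of a number 9 percentage points lower from compound 1 to compound 3 (within the scatter) is therefore expected to be small and downward, and it may well stay within the scatter. For compound 3 the estimate in this assay is 6%, with a range from -8% to 22%.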

Compound 3, a percentage reported as inhibition, at one concentration (the size of the read-out at that concentration, not a potency): 10%
Estimate against measurement, compound 3: 4 percentage points below; the range from low to high includes it.
By their numbers in this assay, from the lowest: compounds 2, 3 and 1 (each within the scatter of the next, the first and the last beyond it).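

In this assay, within the data shown here, the exchange of benzylamino for sulfanyl on this aromatic carbon, next to the ring nitrogen, gives a number 5 percentage points lower from compound 1 to compound 3 (within the scatter) and is the first single change that can be read on its own. The benzylamino group, with its six-membered aromatic ring of carbon only, can therefore give way to sulfanyl, which has no ring, without a change in this read-out that stands clear of the scatter. No measurement bears on why the exchange has so little effect, so the result describes the outcome without explaining it.

The compounds shown leave open whether any other group on this carbon, such as a simple amine, a methoxy group or a longer chain such as phenethylamino, would move the number beyond the scatter. They also leave open how the shared core would respond at other concentrations, since each number here comes from a single tested concentration and is not a potency.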